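This account rests on a few compounds, and the source may have more. Where it says the series, first, only, none or still open, it means among the compounds named here.

In an ADME assay on HFF cells (Homo sapiens) for cytotoxicity, with a stated time of 8 days (a higher number here means that more compound is tolerated, a lower number that less compound is tolerated), compound 1 (`CCOc1nc(N)nc2c1ncn2/C=C1/CC1(CO)CO`) reads > 300000 nM, which is a limit of the assay. Compound 2 (`CCCNc1nc(N)nc2c1ncn2/C=C1/CC1(CO)CO`) reads > 300000 nM, again a limit and not a number, so its standing is known only as a limit. Within the data shown here, the one measured step that bears on what follows is a step that the two limits leave unreadable from compound 1 to compound 2, which came from propylamino in place of ethoxy on an aromatic carbon and offers no size to carry over. The only other ground is the limit of > 300000 nM in this assay, at which 2 of the 2 values shown sit. Compound 3 (`CC(C)CNc1nc(N)nc2c1ncn2/C=C1/CC1(CO)CO`) differs from compound 2 by methyl in place of hydrogen on a saturated chain carbon bound to two saturated chain carbons, which turns propylamino to isobutylamino. No step beyond the scatter, in either direction, is therefore expected in this assay. The expected change is a number no higher from compound 2 to compound 3 (the limit leaves the size open). For compound 3 the estimated value is 300000 nM, with an expected range from 100000 nM to 500000 nM, and the assay may well report only a limit again.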

Compound 3, half-maximal cytotoxic concentration: > 300000 nM
Compound 3 gave a limit, no number (the forecaster's own chance of this, stated with the estimate: 80%); the middle value sits exactly at the limit.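

Among these compounds, compound 1, compound 2 and compound 3 all read as limits and not numbers, so no step among them can be read in this assay: the limit of > 300000 nM in this assay, at which 3 of the 3 values shown sit. Where the half-maximal cytotoxic concentration of each of these compounds lies, and whether they differ at all, stays open.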